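A few compounds are considered here, and "the series" means these few. Any claim that something is new, unique, unknown or untested is made for them only; others in the source may bear on it.

Measured compounds:
compound 1 `CSc1ccc(/C=N/n2c(Cc3ccc(S(C)(=O)=O)cc3)n[nH]c2=S)cc1`, 50000 nM
compound 2 `CS(=O)(=O)c1ccc(Cc2n[nH]c(=S)n2/N=C/c2ccc(Cl)cc2)cc1`, 50000 nM
compound 3 `CS(=O)(=O)c1ccc(Cc2n[nH]c(=S)n2/N=C/c2ccc(F)cc2)cc1`, 100000 nM

All three were read in a functional assay on HeLa cells (Homo sapiens) for cytotoxicity, read by MTT assay, with a stated time of 48 h; a higher number here means that more compound is needed for the effect, a lower number that less compound is needed. Compound 3 is separated from compound 1 by a 2.0-fold higher number from compound 1 to compound 3 (0.30 log units; within the scatter) and from compound 2 by a 2.0-fold higher number from compound 2 to compound 3 (0.30 log units; within the scatter), so within this set it stands apart from neither. The change to compound 4 `CS(=O)(=O)c1ccc(Cc2n[nH]c(=S)n2/N=C/c2ccc(-c3ccccc3)cc2)cc1` is phenyl in place of fluoro on an aromatic carbon. Among the compounds with values here, the steps that bear on it are the swaps at the same aromatic carbon, no change at the digits printed from compound 1 to compound 2 (within the scatter), a 2.0-fold higher number from compound 1 to compound 3 (0.30 log units; within the scatter) and a 2.0-fold higher number from compound 2 to compound 3 (0.30 log units; within the scatter), none of which moved the number beyond the scatter. A step of no more than the scatter is therefore expected for a 1.4-fold lower number from compound 3 to compound 4 (0.15 log units; within the scatter). Compound 4 is estimated at 70000 nM, with a range from 30000 nM to 200000 nM.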

Compound 4, half-maximal effective concentration: 50000 nM
Compound 4: the middle estimate sits 1.4-fold (0.15 log units) above what was measured; the range from low to high includes it.
By their numbers in this assay, from the lowest: compounds 1, 2, 4 and 3 (each within the scatter of the next).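

Within the data shown here, with phenyl, a whole six-membered aromatic ring enters at this aromatic carbon, yet this assay shows a 2.0-fold lower number from compound 3 to compound 4 (0.30 log units; within the scatter) and also no change at the digits printed from compound 2 to compound 4 (within the scatter) as well as no change at the digits printed from compound 1 to compound 4 (within the scatter) among the steps to the earlier compounds. This position, para to a large group, has therefore now taken a ring as well as fluoro, chloro and methylsulfanyl with no step beyond the scatter. From the compounds shown here alone, whether an amine or a carboxylic acid here would shift the number remains open. No available evidence explains these readings.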